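The source may hold more compounds than are shown below. What is called first, only, known or untested is meant among the compounds shown, and "the series" means these compounds.

Working notes on the series in a functional assay on MCF7 cells (Homo sapiens) for cytotoxicity, read by MTT assay, with a stated time of 24 h; a higher number here means a weaker inhibitor, a lower number a stronger inhibitor. Compound 1 (`CCNc1cc(-c2ccc(NC(=O)Nc3ccc(C)cc3)cc2C)ccn1`) gives 9210 nM, and compound 2 (`CCNc1cc(-c2ccc(NC(=O)Nc3ccc(C)cc3)cc2C(F)(F)F)ccn1`) gives 9470 nM. Within the data shown here, the two numbers cannot be told apart: the only measured step, a 1.0-fold higher number from compound 1 to compound 2 (0.01 log units; within the scatter), is trifluoromethyl in place of methyl on an aromatic carbon, and it lies within the scatter. Among the measured compounds shown here, compound 2 therefore stands level with its one measured neighbour, and both sit in the same range.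

Compound 3 (`CCNc1cc(-c2ccc(NC(=O)Nc3cccc4ccccc34)cc2C(F)(F)F)ccn1`) keeps the core of compound 2 and changes the other end of the molecule: naphthalen-1-yl in place of 4-methylphenyl on an amide-type nitrogen. In words, naphthalen-1-yl stands in place of 4-methylphenyl on an amide-type nitrogen. The measured step lies at a different place, so it gives no direct size for this change and only shows that one exchange on the core left the number unmoved. No change at the amide-type nitrogen has been measured, so no direction can be argued from the data, and no shift beyond the scatter is expected. The expected step is a 1.2-fold lower number from compound 2 to compound 3 (0.07 log units; within the scatter). Compound 3 is estimated at 8000 nM, with an expected range of 3000 nM to 20000 nM.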

Compound 3, half-maximal inhibitory concentration: 16300 nM
The estimate for compound 3 lay 2.0-fold (0.31 log units) below the measured number; measured number inside the range.
By their numbers in this assay, from the lowest: compounds 1, 2 and 3 (each within the scatter of the next).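

In this assay the amide-type nitrogen now has an exchange of its own: naphthalen-1-yl in place of 4-methylphenyl gives a 1.7-fold higher number from compound 2 to compound 3 (0.24 log units; within the scatter), so the two groups cannot be told apart at this position. The earlier pair showed this only for trifluoromethyl and methyl on the core, whereas compound 3 shows that a second six-membered aromatic ring of carbon only can enter at the other end of the molecule without a step beyond the scatter. Nothing available offers an explanation for this outcome or gives a measured property of either group.

Still open, from the compounds shown here alone, is whether any exchange at the amide-type nitrogen can move the number beyond the scatter, for example an alkyl chain in place of the aromatic group, or a carboxylic acid or an amine carried on the phenyl ring in place of the methyl of 4-methylphenyl. Also open, going by these compounds, is whether the ethyl group on the other amine matters, which a longer chain or a free amine at that place would test.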